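Working notes: nitro to bromo on the aromatic carbon

This account rests on a few compounds, and the source may have more. Where it says the series, first, only, none or still open, it means among the compounds named here.

Values so far in a functional assay on HepG2 cells (Homo sapiens) for inhibition, read by MTT assay, with a stated time of 48 h (a higher number here means a weaker inhibitor, a lower number a stronger inhibitor), for this series
- compound 1 `Cc1ccc(/C=C2\SC(=O)N(CC(=O)Nc3c(C)n(C)n(-c4ccccc4)c3=O)C2=O)cc1` gives 57600 nM
- compound 2 `Cc1c(NC(=O)CN2C(=O)S/C(=C\c3ccc([N+](=O)[O-])cc3)C2=O)c(=O)n(-c2ccccc2)n1C` gives 84300 nM
- compound 3 `Cc1c(NC(=O)CN2C(=O)S/C(=C\c3ccc(Br)cc3)C2=O)c(=O)n(-c2ccccc2)n1C` is not yet measured

Within the data shown here, compound 2 stands within the scatter of compound 1, the only other measured compound. bromo in place of nitro on an aromatic carbon is the change that gives compound 3, bromo in place of nitro on an aromatic carbon. Among the measured compounds shown here, only one measured step bears on it, nitro in place of methyl on an aromatic carbon, which gave a 1.5-fold higher number from compound 1 to compound 2 (0.17 log units; within the scatter) and so stayed small. The expected change is a 1.3-fold lower number from compound 2 to compound 3 (0.11 log units; within the scatter) and so nothing beyond the scatter is expected, in either direction. For compound 3 the estimated value is 65000 nM (range 30000 nM to 120000 nM).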

Compound 3, half-maximal inhibitory concentration: 19200 nM
For compound 3 the middle estimate is 3.4-fold (0.53 log units) above the measured one, outside the stated range (below it).
By their numbers in this assay, from the lowest: compound 3; then compounds 1 and 2 (each within the scatter of the next).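

In this assay this aromatic carbon proves sensitive to its substituent: the methyl and nitro compounds stayed within the scatter of each other, but bromo in place of nitro gives a 4.4-fold lower number from compound 2 to compound 3 (0.64 log units; beyond the scatter) and bromo in place of methyl gives a 3.0-fold lower number from compound 1 to compound 3 (0.48 log units; beyond the scatter) in this series. Bromo therefore separates from both other groups here, by modest steps. Nothing available explains the difference.

Open, going by these compounds, is whether chloro, iodo or an amine at this carbon would read like bromo, and whether the bromo gain persists with other changes on the shared core.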